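A few compounds are considered here, and "the series" means these few. Any claim that something is new, unique, unknown or untested is made for them only; others in the source may bear on it.

Of the compounds shown here, three built on a shared core have been measured in a functional assay on NCI-H1975 cells (Homo sapiens) for inhibition, read by CellTiter-Glo, with a stated time of 72 h; a higher number here means a weaker inhibitor of growth, a lower number a stronger inhibitor of growth. Compound 1 `C=CC(=O)Nc1cc(Nc2ncc(Cl)c(Nc3ccccc3S(=O)(=O)C(C)C)n2)c(OC)cc1N1CCN(C2CCCCC2)CC1` gives 77 nM, compound 2 `C=CC(=O)Nc1cc(Nc2ncc(Cl)c(Nc3c(F)cccc3F)n2)c(OC)cc1N1CCN(C)CC1` gives 130 nM, and compound 3 `C=CC(=O)Nc1cc(Nc2ncc(Cl)c(N(C)c3cccc(C(F)(F)F)c3)n2)c(OC)cc1N1CCN(C)CC1` gives 1800 nM. Compound 2 thus stands second highest of the three numbers; its nearest neighbour is compound 1, whose value lies within the scatter of it, while compound 3 lies far off, the step of a 14-fold higher number from compound 2 to compound 3 (1.14 log units; beyond the scatter) being a large one.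

Compound 4 `C=CC(=O)Nc1cc(Nc2ncc(Cl)c(Nc3ccccc3S(=O)(=O)N(C)C)n2)c(OC)cc1N1CCN(C)CC1` has not yet been measured in this assay. It differs from compound 2 by 2-(dimethylsulfamoyl)phenyl in place of 2,6-difluorophenyl on a nitrogen on an aromatic ring. For the measured compounds named here, only one measured step touches this part of the molecule, the step from compound 2 to compound 3, and that one replaced the whole (2,6-difluorophenyl)amino group, methyl on the nitrogen included, and moved the number a long way. The change to compound 4 leaves the nitrogen as it is and swaps only the phenyl on it, and the 2-(dimethylsulfamoyl)phenyl that enters resembles the group carried by compound 1, whose value of 77 nM sits within the scatter of compound 2. Compound 4 is therefore expected to show a step of a 1.4-fold lower number from compound 2 to compound 4 (0.14 log units; within the scatter), nothing beyond the scatter. Compound 4 is estimated at 95 nM, with a range from 30 nM to 300 nM.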

Compound 4, concentration for 50% growth inhibition: 31 nM
Compound 4: the middle estimate sits 3.1-fold (0.49 log units) above what was measured; the measured number falls inside the stated range.
By their numbers in this assay, from the lowest: compound 4; then compounds 1 and 2 (each within the scatter of the next); then compound 3.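

For the compounds shown here, with the nitrogen left as it is and only the ring on it exchanged, 2-(dimethylsulfamoyl)phenyl in place of 2,6-difluorophenyl gives, in this assay, a 4.2-fold lower number from compound 2 to compound 4 (0.62 log units; beyond the scatter) and so moves the number downward, whereas the only earlier step at this place went upward. That earlier step, a 14-fold higher number from compound 2 to compound 3 (1.14 log units; beyond the scatter), changed the ring and added a methyl on the nitrogen together, so it could not show whether the ring alone matters; the new step shows that it does, and that a change at this place can lower the number as well as raise it. The entering group brings more heavy atoms and two hydrogen-bond acceptors where the leaving group has none, but nothing given here ties the lower number to either count or explains the step.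

The compounds shown leave open whether the lower number holds when the dimethylamino part of the sulfamoyl group gives way to a pyrrolidine or a morpholine, or when a methylsulfonyl group or a carboxamide stands in place of the whole sulfamoyl group. They also leave open how much of the rise to compound 3 belongs to the methyl on the nitrogen and how much to the trifluoromethyl-bearing ring.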